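The compounds below may be only part of what the source reports. "The series", "measured", "known", "first", "only" and "open" are said of these compounds alone.

Going by the values given here, compound 3 `CC(C)[C@H](c1ccc(C(=O)NCc2nn[nH]n2)cc1)N1C(=O)C(c2cc(Cl)cc(Cl)c2)=N[C@]12CC[C@@H](C(C)(C)C)CC2` gives 2200 nM in a functional assay on CHO cells for antagonist activity at Glucagon receptor (Homo sapiens), read by cAMP accumulation, with stated times of 30 min and 45 min (on this read-out lower numbers stand for stronger inhibition and higher numbers for weaker inhibition), the highest of the three numbers measured so far. Compound 1 `C[C@H](c1ccc(C(=O)NCCC(=O)O)cc1)N1C(=O)C(c2ccc(F)cc2)=N[C@]12CC[C@@H](C(C)(C)C)CC2` gives 430 nM and compound 2 `C[C@H](c1ccc(C(=O)NCCC(=O)O)cc1)N1C(=O)C(c2cccc(C3CC3)c2)=N[C@]12CC[C@@H](C(C)(C)C)CC2` gives 340 nM in this assay, both clearly lower than the number for compound 3. Compound 4 `CCC[C@H](c1ccc(C(=O)NCc2nn[nH]n2)cc1)N1C(=O)C(c2cc(Cl)cc(Cl)c2)=N[C@]12CC[C@@H](C(C)(C)C)CC2` differs from compound 3 by propyl in place of isopropyl on a saturated chain carbon bound to an amide-type nitrogen in a ring and an aromatic carbon. Among the compounds with values here, the only measured step, a 1.3-fold lower number from compound 1 to compound 2 (0.10 log units; within the scatter), concerns a different part of the shared core and does not bear directly on this change; no measured pair shows the same exchange of chains. With nothing to point in either direction, the expected step of a 1.1-fold higher number from compound 3 to compound 4 (0.06 log units; within the scatter) is none beyond the scatter. Compound 4 is therefore estimated at 2500 nM in this assay, with a range from 1000 nM to 6000 nM.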

Compound 4, half-maximal inhibitory concentration: 220 nM
Beside the measured number, compound 4's estimate is 11-fold (1.06 log units) above it, and the stated range ends above it.
By their numbers in this assay, from the lowest: compounds 4, 2 and 1 (each within the scatter of the next); then compound 3.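

Exchanging isopropyl for propyl keeps the same three carbons, yet in this assay it gives a 10-fold lower number from compound 3 to compound 4 (1.00 log units; beyond the scatter) and so shows that this position responds strongly to how those carbons are joined. The earlier step between compound 1 and compound 2 involved a different place and could not show this. No measurement here explains the difference between the two chains. Still open, on these data alone, is whether a longer chain such as butyl would go further in the same direction. Also open, as far as these compounds go, is whether the same exchange has a similar effect in compounds carrying the carboxylic acid side chain of compound 1.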